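The source may hold more compounds than are shown below. What is called first, only, known or untested is meant among the compounds shown, and "the series" means these compounds.

Three compounds have been measured in an ADME assay on PBMC cells (Homo sapiens) for cytotoxicity; a higher number here means that more compound is tolerated, a lower number that less compound is tolerated:

compound 1 `COC(=O)c1cccc(OC(c2ccc(C(F)(F)F)cc2)C2CCN(C(C)CCNC(=O)c3c(Cl)cncc3Cl)CC2)n1` — 14600 nM
compound 2 `Cc1cccc(OC(c2ccc(C(F)(F)F)cc2)C2CCN(C(C)CCNC(=O)c3c(Cl)cncc3Cl)CC2)n1` — 6700 nM
compound 3 `CC(CCNC(=O)c1c(Cl)cncc1Cl)N1CCC(C(Oc2ccc(C(F)(F)F)cc2)c2ccc(C(F)(F)F)cc2)CC1` — 3100 nM

Compound 3 gives the lowest of these three numbers, so it is the one of which the cells tolerate least. The steps that lead to it are a 2.2-fold lower number from compound 2 to compound 3 (0.33 log units; beyond the scatter) and a 4.7-fold lower number from compound 1 to compound 3 (0.67 log units; beyond the scatter); both are beyond the scatter yet modest, and both replace a pyridin-2-yl carrying a small group with 4-(trifluoromethyl)phenyl on the same oxygen. Compound 4 `CC(CCNC(=O)c1c(Cl)cncc1Cl)N1CCC(C(Oc2cccc(Cl)n2)c2ccc(C(F)(F)F)cc2)CC1` differs from compound 3 by 6-chloropyridin-2-yl in place of 4-(trifluoromethyl)phenyl on an oxygen on a saturated carbon. This is the opposite kind of move: the 4-(trifluoromethyl)phenyl leaves and a pyridin-2-yl carrying a small group comes back. The steps from compound 2 and from compound 1 to compound 3 therefore bear on it most directly, and they suggest a modest rise in this assay rather than a fall or no change. For compound 4 the expected step is a 2.1-fold higher number from compound 3 to compound 4 (0.32 log units; beyond the scatter). On that basis compound 4 is estimated at 6500 nM, with a plausible range from 3000 nM to 14000 nM.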

Compound 4, half-maximal cytotoxic concentration: > 32500 nM
Compound 4: a limit, no number; the forecaster's own chance of this, stated with the estimate: 10%; middle value at least 5.0-fold (0.69 log units) away from the limit.
By their numbers in this assay, from the lowest: compound 3; then compound 2; then compound 1. At a limit, above all of these: compound 4.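

In this assay compound 4 gives > 32500 nM, which is a limit of the assay and not a number. Going by these compounds alone, changing only the group on this oxygen gives an at least 10-fold higher number from compound 3 to compound 4 (1.02 log units; beyond the scatter), a large step that shows this position can shift the tolerated concentration much further than the modest steps among the earlier compounds suggested. The small group on the pyridin-2-yl also counts, as chloro in place of methyl gives an at least 4.8-fold higher number from compound 2 to compound 4 (0.68 log units; beyond the scatter) and chloro in place of methoxycarbonyl gives an at least 2.2-fold higher number from compound 1 to compound 4 (0.34 log units; beyond the scatter).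

As far as these compounds go, the limit leaves open how much compound the cells would tolerate for compound 4, so the true size of all three steps remains unknown. From the compounds shown here alone, it is also open whether this high tolerance is particular to chloro, or would persist with fluoro, a nitrile or an amine in its place.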